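The source may hold more compounds than are shown below. What is called first, only, known or untested is meant among the compounds shown, and "the series" means these compounds.

In a functional assay (Cardiac muscle cell, Rattus norvegicus, strain Sprague-Dawley) for inhibition, read by LDH release, with a stated time of 6 h (a lower number here means that less compound is needed, a higher number that more compound is needed for the effect), compound 1 (`COC(=O)c1oc2ccccc2c1NC(=O)CSc1ccc(OC)cc1`) gives 752 nM and compound 2 (`COC(=O)c1oc2ccccc2c1NC(=O)COc1ccc(Br)cc1`) gives 1180 nM, two numbers within the scatter of each other. Compound 3 (`COC(=O)c1oc2ccccc2c1NC(=O)CSc1ccccn1`) carries (pyridin-2-yl)sulfanyl in place of 4-bromophenoxy on a saturated chain carbon bound to a carbonyl carbon. Among the measured compounds shown here, no measured pair isolates this change, so no step beyond the scatter is expected in this assay, and no direction is favoured. The estimated step, a 1.2-fold lower number from compound 2 to compound 3 (0.07 log units; within the scatter), therefore stays small. The estimate for compound 3 is 1000 nM, with an expected range of 300 nM to 3000 nM.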

Compound 3, half-maximal effective concentration: 653 nM
Estimate against measurement, compound 3: 1.5-fold (0.19 log units) above, within the range that was stated.
By their numbers in this assay, from the lowest: compounds 3, 1 and 2 (each within the scatter of the next).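

Swapping 4-methoxyphenyl for pyridin-2-yl on a sulfur gives a 1.2-fold lower number from compound 1 to compound 3 (0.06 log units; within the scatter) in this assay and is the first single-place change read at that sulfur. With (pyridin-2-yl)sulfanyl in place of 4-bromophenoxy on a saturated chain carbon bound to a carbonyl carbon, the series shows a 1.8-fold lower number from compound 2 to compound 3 (0.26 log units; within the scatter) and so no step beyond the scatter for this change. No measurement available here bears on the cause of either step. From the compounds shown here alone, whether an amine or a carboxylic acid in place of pyridin-2-yl on a sulfur would give a step beyond the scatter stays open. Going by these compounds, the effect of a longer chain also stays open.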